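This account rests on a few compounds, and the source may have more. Where it says the series, first, only, none or still open, it means among the compounds named here.

For the measured compounds named here, in a functional assay on the whole organism for inhibition, with Rattus norvegicus as the target, read by paw edema, with stated times of 1 h and 3 h (on this read-out higher numbers stand for an effect only at larger amounts of compound and lower numbers for an effect already at smaller amounts), compound 2 `C/C(=N\OCCO)c1ccc(Cl)cc1` gives 29 mg/kg, the lower of the two numbers measured so far. Compound 1 `C/C(=N\OCCCCCC(=O)O)c1ccc(Cl)cc1` gives 92 mg/kg. Compound 3 `CC(=O)OCCO/N=C(\C)c1ccc(Cl)cc1` has acetyl in place of hydrogen on an oxygen on a saturated carbon. Going by the values given here, the only measured step that bears on this is a 3.2-fold lower number from compound 1 to compound 2 (0.50 log units; beyond the scatter), a modest change. It swapped a different group, so it is only a loose guide, and no acetyl change has been measured. The expected result is a 1.2-fold higher number from compound 2 to compound 3 (0.08 log units; within the scatter), which would stay within the scatter. For compound 3 the estimated value is 35 mg/kg, with an expected range of 14 mg/kg to 85 mg/kg.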

Compound 3, dose for half-maximal effect: 43 mg/kg
The estimate for compound 3 lay 1.2-fold (0.09 log units) below the measured number; the range from low to high includes it.
By their numbers in this assay, from the lowest: compounds 2 and 3 (each within the scatter of the next); then compound 1.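

Acetyl on this oxygen is the first change shown at the hydroxy end of the chain, and in this assay it gives a 1.5-fold higher number from compound 2 to compound 3 (0.17 log units; within the scatter), so the hydrogen there can be replaced by acetyl without moving the number outside the scatter. The acetoxy group also stays apart from the 3-carboxypropyl group, with a 2.1-fold lower number from compound 1 to compound 3 (0.33 log units; beyond the scatter). No available evidence explains either step. Going by these compounds, it remains open whether a benzoyl or a methyl on this same oxygen would also stay within the scatter of compound 2.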